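The source may hold more compounds than are shown below. What is called first, only, known or untested is meant among the compounds shown, and "the series" means these compounds.

Series notes. Compound 1 `COc1ccc(OCC(=O)Nc2cccc(NC(=O)c3ccc(N(C)C)cc3)c2)cc1OC` and compound 2 `N#Cc1ccc(C(=O)Nc2cccc(NC(=O)COc3ccc4c(=O)ccoc4c3)c2)cc1` share a core carrying two amide arms. In an assay on isolated protein for inhibition of Rho-associated protein kinase 2 (Homo sapiens), read by scintillation counting, radiometric assay and 33P incorporation, with a stated time of 40 min, in the presence of a further agent that is not named here (on this read-out lower numbers stand for stronger inhibition and higher numbers for weaker inhibition), compound 1 gives > 10000 nM, which is a limit of the assay rather than a number; see (the limit of > 10000 nM in this assay, at which 1 of the 2 values shown sits). In this assay, for the measured compounds named here, compound 2 gives 15 nM, the only defined number in the set, so compound 2 stands as the single compound with a measured value against which a new analogue can be judged. Compound 3 `O=C(COc1ccc2c(=O)ccoc2c1)Nc1cccc(NC(=O)c2cnc(C(F)(F)F)s2)c1` differs from compound 2 in one place: 2-(trifluoromethyl)-1,3-thiazol-5-yl in place of 4-cyanophenyl on a carbonyl carbon. Going by the values given here, no step between two measured compounds covers this change, so its size cannot be read from the data so far. The expectation is that compound 3 stays close to compound 2, with a step of a 2.0-fold higher number from compound 2 to compound 3 (0.30 log units; within the scatter) that may sit within the scatter or just beyond it, toward weaker inhibition. The estimate for compound 3 in this assay is 30 nM, in a range from 8 nM to 120 nM.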

Compound 3, half-maximal inhibitory concentration: 10 nM
Estimate against measurement, compound 3: 3.0-fold (0.48 log units) above; the range from low to high includes it.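

In this assay the change reads as a 1.5-fold lower number from compound 2 to compound 3 (0.18 log units; within the scatter), so 2-(trifluoromethyl)-1,3-thiazol-5-yl and 4-cyanophenyl, on a carbonyl carbon whose other neighbour is amide-type nitrogen, are not told apart. For the compounds shown here, this is the first reading at this position: a five-membered aromatic ring with 2 hetero atoms serves there as well as a six-membered aromatic ring of carbon only, and compound 3, at 10 nM, carries no nitrile. Going by these compounds alone, nothing measured so far bears on why the two groups read alike.

Compound 1 gives > 10000 nM, a limit of the assay and not a number, and it differs from compound 2 in more than one place, so the share of each arm cannot be read. Still open, from the compounds shown here alone, is how an amine, a carboxylic acid or the thiazole without its trifluoromethyl would read on that carbonyl carbon.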